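The compounds below may be only part of what the source reports. "The series", "measured", "known", "first", "only" and "open" are said of these compounds alone.

The core seen in compound 1 `COc1cc(NC(C)CCCNC(=O)Nc2ccc(Cl)c(C(F)(F)F)c2)c2ncccc2c1` is shared throughout; in a functional assay on L1210 cells (Mus musculus) for inhibition, read by MTT assay, with a stated time of 4 days (on this read-out higher numbers stand for weaker inhibition and lower numbers for stronger inhibition), compound 1 gives 3600 nM. Compound 2 `COc1cc(NC(C)CCCNC(=O)NNC(=O)NCCCCCO)c2ncccc2c1` carries a ((5-hydroxypentyl)carbamoyl)amino group instead, and in this assay compound 2 gives > 250000 nM, which is a limit of the assay and not a number. Compound 3 `COc1cc(NC(C)CCCNC(=O)NNC(=O)NCCO)c2ncccc2c1` carries ((2-hydroxyethyl)carbamoyl)amino, and in this assay compound 3 gives > 250000 nM, again only a limit. Compound 3 thus stands at a bound, not at a measured point: the step of an at least 69-fold higher number from compound 1 to compound 3 (1.84 log units; beyond the scatter) is large, while the step that the two limits leave unreadable from compound 2 to compound 3 cannot be sized, since both of these compounds sit at the limit of > 250000 nM in this assay, at which 2 of the 3 values shown sit.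

Compound 4 `COc1cc(NC(C)CCCNC(=O)NNC(=O)NC(CO)(CO)CO)c2ncccc2c1` differs from compound 3 by 2-hydroxy-1,1-bis(hydroxymethyl)ethyl in place of 2-hydroxyethyl on an amide-type nitrogen. Going by the values given here, the change stays within the ((hydroxyalkyl)carbamoyl)amino class that produced the steps of an at least 69-fold higher number from compound 1 to compound 2 (1.84 log units; beyond the scatter) and an at least 69-fold higher number from compound 1 to compound 3 (1.84 log units; beyond the scatter), and no measured step separates one such group from another beyond the limit. The expectation is therefore no readable change: a number no higher from compound 3 to compound 4 (the limit leaves the size open) is expected in this assay. Compound 4 is estimated at 250000 nM, within 100000 nM to 1000000 nM, most likely reported again as a limit.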

Compound 4, half-maximal inhibitory concentration in the L1210 assay: > 250000 nM
Compound 4: no number, only a limit; the forecaster's own chance of this, stated with the estimate: 85%; the middle value lies on the limit itself.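

In the L1210 assay, the step of an at least 69-fold higher number from compound 1 to compound 4 (1.84 log units; beyond the scatter) places the 2-hydroxy-1,1-bis(hydroxymethyl)ethyl group with the 5-hydroxypentyl and 2-hydroxyethyl groups on this amide-type nitrogen; the steps among compounds 2, 3 and 4 cannot be read, as all three stand at a limit. In a physicochemical assay for inhibition, read by spectrophotometry, tested at 100 uM (on this read-out lower numbers stand for less inhibition and higher numbers for more inhibition at the one concentration tested (going by the name of the read-out)), compound 3 gives 27% and compound 4 gives 49%. Going by these compounds alone, the exchange of 2-hydroxyethyl for 2-hydroxy-1,1-bis(hydroxymethyl)ethyl thus gains a readable size for the first time in the physicochemical assay, as a number 22 percentage points higher from compound 3 to compound 4 (beyond the scatter), though this is a read-out at one concentration and not a potency.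

Open, on these data alone, is whether a carboxylic acid or an amine at the end of the chain in place of the hydroxy would give a number in the L1210 assay. Also open, as far as these compounds go, is how the percentages in the physicochemical assay relate to the cell read-out, with only limits available for compound 3 and compound 4.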